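Compound 3 after one measured permeability step

The source may report more compounds than this note shows. Statements on the series, on what has been measured and on what is new or still open speak of the compounds shown alone.

In an ADME assay on MDCK-II cells (Canis lupus familiaris) for permeability (a higher number here means that the compound crosses the layer faster, a lower number that the compound crosses the layer more slowly), compound 1 `CC(C)Oc1cc(Oc2ccc(S(C)(=O)=O)cc2)cc(-c2nccc(=O)[nH]2)c1` gives 24 10^-6 cm/s. Compound 2 `Cc1cc(=O)[nH]c(-c2cc(Oc3ccc(S(C)(=O)=O)cc3)cc(OC(C)C)c2)n1` gives 4.8 10^-6 cm/s, the lower of the two numbers. Compound 3 `COc1cnc(-c2cc(Oc3ccc(S(C)(=O)=O)cc3)cc(OC(C)C)c2)[nH]c1=O` carries a group of 9 heavy atoms (5 carbon, 2 nitrogen, 2 oxygen; one six-membered aromatic ring with 2 hetero atoms) in place of a group of 8 heavy atoms (5 carbon, 2 nitrogen, 1 oxygen; one six-membered aromatic ring with 2 hetero atoms), on an aromatic carbon, on an aromatic carbon of a six-membered aromatic ring of carbon only. Going by the values given here, one measured step bears on this, and only indirectly: a 5.0-fold lower number from compound 1 to compound 2 (0.70 log units; beyond the scatter), with methyl in place of hydrogen on an aromatic carbon. Among the compounds with values here, no measured step covers the entering group, so a modest rise, smaller than that step, is expected in this assay. The expected step is a 2.1-fold higher number from compound 2 to compound 3 (0.32 log units; beyond the scatter). For compound 3 the estimate is 10 10^-6 cm/s, with a range of 4 10^-6 cm/s to 24 10^-6 cm/s.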

Compound 3, apparent permeability: 3.9 10^-6 cm/s
The estimate for compound 3 lay 2.6-fold (0.41 log units) above the measured number, and the stated range ends above it.
By their numbers in this assay, from the lowest: compounds 3 and 2 (each within the scatter of the next); then compound 1.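

Methoxy in place of hydrogen on the six-membered aromatic ring with 2 hetero atoms gives a 6.2-fold lower number from compound 1 to compound 3 (0.79 log units; beyond the scatter) in this assay and so also stands well under compound 1, as the methyl compound does. Exchanging the methyl-bearing ring for the methoxy-bearing one gives a 1.2-fold lower number from compound 2 to compound 3 (0.09 log units; within the scatter) and leaves the two compounds indistinguishable in this assay. No supporting data explain these numbers. Open, on these data alone, is whether a fluorine or an amine on that ring would read like methyl and methoxy or return towards compound 1.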